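Swapping the fluorobenzyl arm for a dimethoxybenzyl arm

The compounds below may be only part of what the source reports. "The series", "measured", "known", "first", "only" and "open" are said of these compounds alone.

Measured so far:
- Compound 1, `O=C(NCc1cn(Cc2ccc(F)cc2)nn1)c1cn(-c2ccccc2)nc1-c1ccccc1`, in a functional assay on MCF7 cells (Homo sapiens) for antiproliferative activity, read by sulforhodamine B assay, with a stated time of 48 h (a higher number here means a weaker inhibitor of growth, a lower number a stronger inhibitor of growth), gives 7000 nM.
- Compound 2, `O=C(NCc1cn(Cc2ccc(F)cc2)nn1)c1cn(-c2ccccc2)nc1-c1ccc(F)cc1`, in this assay gives 55300 nM.
- Compound 3, `COc1ccc(-c2nn(-c3ccccc3)cc2C(=O)NCc2cn(Cc3ccc(F)cc3)nn2)cc1`, in this assay gives 460 nM.

Compound 3 stands lowest of the three numbers, which here means the strongest growth inhibitor. Its nearest neighbour is compound 1, reached by a 15-fold lower number from compound 1 to compound 3 (1.18 log units; beyond the scatter), and the furthest is compound 2, reached by a 120-fold lower number from compound 2 to compound 3 (2.08 log units; beyond the scatter). The other measured step, a 7.9-fold higher number from compound 1 to compound 2 (0.90 log units; beyond the scatter), also sits on the phenyl attached to the shared core.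

Compound 4, `COc1ccc(-c2nn(-c3ccccc3)cc2C(=O)NCc2cn(Cc3cc(OC)cc(OC)c3)nn2)cc1`, differs from compound 3 at a different place: 3,5-dimethoxyphenyl in place of 4-fluorophenyl on a saturated chain carbon bound to an aromatic nitrogen. None of the three measured steps touches this arm; all of them change the other ring. Among the compounds with values here, there is therefore no measured step that bears directly on the change from compound 3 to compound 4, and the expectation can only be that the number stays close to that of compound 3, with no step beyond the scatter predicted in either direction: the estimated step is a 1.3-fold higher number from compound 3 to compound 4 (0.12 log units; within the scatter). The value for compound 4 in this assay is thus estimated at 600 nM, within a range of 150 nM to 2500 nM.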

Compound 4, concentration for 50% growth inhibition: 700 nM
Beside the measured number, compound 4's estimate is 1.2-fold (0.07 log units) below it; low and high end bracket the measured number.
By their numbers in this assay, from the lowest: compounds 3 and 4 (each within the scatter of the next); then compound 1; then compound 2.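

Every earlier step sat on the phenyl attached to the shared core, and all of those steps lay beyond the scatter in this assay. Within the data shown here, with a 1.5-fold higher number from compound 3 to compound 4 (0.18 log units; within the scatter), the first measured change on the other arm, on a saturated chain carbon bound to an aromatic nitrogen, gives a difference that cannot be told from the scatter, even though the swap of 4-fluorobenzyl to 3,5-dimethoxybenzyl is no small edit: the group gains heavy atoms, loses its fluorine and brings in 2 hydrogen-bond acceptors where there were 0. So, for this one pair, the arm accepts a larger, differently substituted ring with no readable change in growth inhibition, though no measurement at hand offers a reason for this.

From the compounds shown here alone, this single pair rests on the methoxy-bearing core of compound 3, so it remains open whether the same arm swap would be as quiet on the cores of compound 1 or compound 2. Going by these compounds, it is also open how far this tolerance reaches, for example with an amine or a carboxylic acid on this ring, or with a longer chain in place of the benzyl link.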